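This account rests on a few compounds, and the source may have more. Where it says the series, first, only, none or still open, it means among the compounds named here.

Compound 1 `O=[N+]([O-])c1ccc(CN2CCC(n3cc(CC(OCc4cc(-c5cccc(Br)c5)no4)c4ccc(Br)cc4)nn3)CC2)cc1` serves as the reference point of the series. In a functional assay on MDA-MB-468 cells (Homo sapiens) for cytotoxicity, with a stated time of 48 h (a lower number here means a stronger inhibitor, a higher number a weaker inhibitor), compound 1 gives only a limit, > 25000 nM. Compound 2 `O=[N+]([O-])c1ccc(CN2CCC(n3cc(CC(OCc4cc(-c5ccccc5Br)no4)c4ccc(Br)cc4)nn3)CC2)cc1` carries a 2-bromophenyl in place of the 3-bromophenyl on an aromatic carbon. In this assay compound 2 likewise gives only a limit, > 25000 nM. The step that the two limits leave unreadable from compound 1 to compound 2 is therefore not readable, both values sitting at the limit of > 25000 nM in this assay, at which 2 of the 2 values shown sit. Compound 3 `O=[N+]([O-])c1ccc(CN2CCC(n3cc(CC(OCc4cc(-c5ccccc5F)no4)c4ccc(Br)cc4)nn3)CC2)cc1` carries the change (2-fluorophenyl in place of 3-bromophenyl on an aromatic carbon). Within the data shown here, no measured step bears on it with a readable size. The estimate for compound 3 is 30000 nM, between 8000 nM and 100000 nM, most probably again a limit. The expected step is a step that the limit leaves unreadable from compound 1 to compound 3.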

Compound 3, half-maximal inhibitory concentration: 4000 nM
Compound 3: middle estimate off by 7.5-fold (0.88 log units), on the high side, and the stated range ends above it.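

In this assay, among these compounds, the 2-fluorophenyl gives the first readable value at this place on the ring, with an at least 6.2-fold lower number from compound 1 to compound 3 (0.79 log units; beyond the scatter). The comparison with the matching bromo compound isolates the halogen, giving an at least 6.2-fold lower number from compound 2 to compound 3 (0.79 log units; beyond the scatter), so fluoro in place of bromo alone moves the number beyond the scatter. Moving bromine around the phenyl ring could not be read, because both bromo compounds stand at a limit: the limit of > 25000 nM in this assay, at which 2 of the 3 values shown sit.

The compounds shown leave open whether a 3-fluorophenyl would read like the 2-fluorophenyl. Going by these compounds, how a 2-chlorophenyl or a 2-methoxyphenyl would read also remains open.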